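Anilinoquinazoline thiourea sulfonamides against a lung cancer cell line

A few compounds are considered here, and "the series" means these few. Any claim that something is new, unique, unknown or untested is made for them only; others in the source may bear on it.

Compound 1 `COc1cc2ncnc(Nc3ccc(C)cc3)c2cc1OCCCCC(=O)Nc1ccc(S(N)(=O)=O)cc1`: 19300 nM
Compound 2 `C#Cc1cccc(Nc2ncnc3ccc(NC(=S)Nc4ccc(S(N)(=O)=O)cc4)cc23)c1`: 13400 nM

In a functional assay on NCI-H1975 cells (Homo sapiens) for antiproliferative activity, read by MTT assay, with a stated time of 72 h (on this read-out lower numbers stand for stronger inhibition and higher numbers for weaker inhibition), compound 1 gives 19300 nM and compound 2 gives 13400 nM. The two numbers lie within the scatter of each other, so compound 2 cannot be set apart from compound 1 on this assay. Compound 3 `CCc1ccc(Nc2ncnc3ccc(NC(=S)Nc4ccc(S(N)(=O)=O)cc4)cc23)cc1` is not yet measured. It differs from compound 2 in one place: 4-ethylphenyl in place of 3-ethynylphenyl on a nitrogen on an aromatic ring. Among the measured compounds shown here, with no measured step of this kind to lean on, a modest weakening, perhaps no more than the scatter, is expected; the estimated step from compound 2 to compound 3 is a 1.6-fold higher number from compound 2 to compound 3 (0.22 log units; within the scatter). Compound 3 is expected to give about 22000 nM, within 8000 nM to 60000 nM.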

Compound 3, half-maximal inhibitory concentration: 38700 nM
Compound 3: middle estimate off by 1.8-fold (0.25 log units), on the low side, within the range that was stated.
By their numbers in this assay, from the lowest: compounds 2, 1 and 3 (each within the scatter of the next, the first and the last beyond it).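

In this assay, the aryl group on this nitrogen matters: 4-ethylphenyl in place of 3-ethynylphenyl gives a 2.9-fold higher number from compound 2 to compound 3 (0.46 log units; beyond the scatter) and so a modest weakening. Both groups have 8 heavy atoms, so the assay separates two groups of equal heavy-atom count. Nothing available explains the loss.

Going by these compounds, the step changes the triple bond and the place of the substituent together, so the share of each remains open. Also open, on these data alone, is how a phenyl group carrying an amine or a carboxylic acid would behave on this nitrogen.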